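The source may hold more compounds than are shown below. What is called first, only, known or untested is meant among the compounds shown, and "the series" means these compounds.

Compound 1, `COc1cc(-c2cc(/C=C/C(=O)c3ccc(Cl)c(Cl)c3)[nH]n2)cc(OC)c1OC`, gives 16% in a functional assay on OVCAR-5 cells (Homo sapiens) for cytotoxicity, read by sulforhodamine B assay, with a stated time of 48 h, tested at 100 uM; on this read-out higher numbers stand for a weaker effect at the one concentration tested and lower numbers for a stronger effect.
Compound 2, `COc1ccc(C(=O)/C=C/c2cc(-c3cc(OC)c(OC)c(OC)c3)n[nH]2)cc1OC`, gives -71% in this assay.
Compound 3, `COc1ccc(C(=O)/C=C/c2cc(-c3cc(OC)c(OC)c(OC)c3)n[nH]2)cc1`, gives -59% in this assay.

Compound 3 stands second highest of the three numbers. Its nearest neighbour is compound 2, and the step of a number 12 percentage points higher from compound 2 to compound 3 (beyond the scatter) is modest; its furthest is compound 1, and the step of a number 75 percentage points lower from compound 1 to compound 3 (beyond the scatter) is large.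

Compound 4 is `COc1cc(-c2cc(/C=C/C(=O)c3ccc(F)c(F)c3)[nH]n2)cc(OC)c1OC`. It differs from compound 3 in one place: 3,4-difluorophenyl in place of 4-methoxyphenyl on a carbonyl carbon.

The measured steps that bear on this change are the two in which the group on the carbonyl carbon was exchanged. The step of a number 87 percentage points lower from compound 1 to compound 2 (beyond the scatter) and the step of a number 75 percentage points lower from compound 1 to compound 3 (beyond the scatter) were both large, and both went from 3,4-dichlorophenyl to a methoxy-bearing phenyl. The change to compound 4 runs the other way, from 4-methoxyphenyl toward a halogen-bearing phenyl, although 3,4-difluorophenyl is not the same group as the 3,4-dichlorophenyl of compound 1. A large step upward in this assay is therefore expected, though not necessarily the full size of the reverse of the step from compound 1 to compound 3.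

Compound 4 is estimated to give -10% in this assay, within -50% to 25%, which is the expected step of a number 49 percentage points higher from compound 3 to compound 4 (beyond the scatter).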

Compound 4, a percentage reported as activity, at one concentration (the size of the read-out at that concentration, not a potency): -24%
Compound 4: middle estimate off by 14 percentage points, on the high side; low and high end bracket the measured number.
By their numbers in this assay, from the lowest: compound 2; then compound 3; then compound 4; then compound 1.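

With 3,4-difluorophenyl on the carbonyl carbon, compound 4 gives -24% in this assay, and the step of a number 40 percentage points lower from compound 1 to compound 4 (beyond the scatter) is large, so the two halogen-bearing phenyl groups are not interchangeable at this position. Moving from the methoxy-bearing groups to 3,4-difluorophenyl also gives large steps, a number 35 percentage points higher from compound 3 to compound 4 (beyond the scatter) and a number 47 percentage points higher from compound 2 to compound 4 (beyond the scatter), which places compound 4 between the two methoxy-bearing compounds and the 3,4-dichlorophenyl compound 1, so that across these four compounds both halogen-bearing groups read higher than both methoxy-bearing groups, with no compound going against that order. Nothing available here accounts for the gap between the two halogen-bearing groups or for the gap between them and the methoxy-bearing groups.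

The compounds shown leave open where a plain phenyl, or a phenyl carrying a trifluoromethyl or a dimethylamino group, would fall at this carbonyl carbon. They also leave open whether this order of stronger and weaker effects, read at a single concentration, would hold at other concentrations, and whether it would survive a change elsewhere in the shared core.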